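The compounds below may be only part of what the source reports. "The series", "measured", "known", "first", "only" and "open" are said of these compounds alone.

Working notes on the series. In a functional assay on Ca-Ski cells (Homo sapiens) for antiproliferative activity, with a stated time of 48 h (on this read-out lower numbers stand for stronger inhibition and higher numbers for weaker inhibition), compound 3 (`O=C(/C=C/c1ccccc1)c1ccc(OCc2ccccc2)cc1O`) stands at > 50000 nM which is a limit and not a number. Compound 1 (`CCCOc1ccc(C(=O)/C=C/c2ccccc2)c(O)c1`) gives > 50000 nM which is also a limit. Compound 2 (`COc1ccc(C(=O)/C=C/c2ccccc2)c(O)c1I`) gives > 50000 nM which is again a limit. Among the measured compounds shown here, the series so far therefore shows the limit of > 50000 nM in this assay, at which 3 of the 3 values shown sit, and no readable number.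

Next comes compound 4 (`CC(=O)Oc1ccc(C(=O)/C=C/c2ccccc2)c(O)c1`). Its change from compound 3 is acetyl in place of benzyl on an oxygen on an aromatic ring, or benzyloxy to acetoxy: acetyl in place of benzyl on an oxygen on an aromatic ring and the rest of the structure stays the same.

For the measured compounds named here, one measured step bears on this change: a step that the two limits leave unreadable from compound 1 to compound 3 and it offers neither a size nor a direction. Going by the values given here, no measured compound carries acetyl on that oxygen. No step beyond the scatter can be expected in either direction, and another limit is the likeliest result, an expectation that rests on the limit of > 50000 nM in this assay, at which 3 of the 3 values shown sit, and nothing firmer.

The expected step is a number no higher from compound 3 to compound 4 (the limit leaves the size open) and the estimate cannot be narrowed further. For compound 4 the estimated value is 50000 nM with an expected range of 20000 nM to 120000 nM in this assay as the working figure.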

Compound 4, half-maximal inhibitory concentration: > 50000 nM
Compound 4: no number, only a limit; the forecaster's own chance of this, stated with the estimate: 80%; the middle value sits exactly at the limit.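

In this assay compound 4 gives > 50000 nM, which is a limit and not a number. No step can be read between compound 4 and compound 3, or between compound 4 and compound 1, since those values are limits too. The compounds shown leave open whether any group on that oxygen changes the read-out at all: the limit of > 50000 nM in this assay, at which 4 of the 4 values shown sit.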